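Swapping Acetamido for Acetoxy on the Sugar Ring

This account rests on a few compounds, and the source may have more. Where it says the series, first, only, none or still open, it means among the compounds named here.

Measured compounds:
compound 1 `CC(=O)N[C@@H]1[C@@H](OC(C)=O)[C@H](OC(C)=O)[C@@H](COC(C)=O)O[C@H]1n1nc(SCc2ccccc2)nc1-c1cc2ccccc2[nH]1` — 15.9 ug/mL
compound 2 `c1ccc(CSc2nc(-c3cc4ccccc4[nH]3)n(Cc3ccccc3)n2)cc1` — 14.8 ug/mL

In a functional assay on MCF7 cells (Homo sapiens) for antiproliferative activity, read by sulforhodamine B assay, with a stated time of 48 h (on this read-out lower numbers stand for stronger inhibition and higher numbers for weaker inhibition), compound 1 gives 15.9 ug/mL. Compound 2, which carries a benzyl group in place of the sugar, gives 14.8 ug/mL in this assay. Compound 1 stands at the high end of these two numbers, but its gap to compound 2 lies within the usual scatter, so the two compounds cannot be told apart on this read-out.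

Compound 3 `CC(=O)OC[C@H]1O[C@@H](n2nc(SCc3ccccc3)nc2-c2cc3ccccc3[nH]2)[C@H](OC(C)=O)[C@@H](OC(C)=O)[C@@H]1OC(C)=O` has not yet been measured in this assay. It differs from compound 1 in one place: acetoxy in place of acetamido on a saturated ring carbon. For the measured compounds named here, no step between two measured compounds is available to show what such a swap does, and the two measured numbers themselves sit close together. I therefore expect the step of a 1.0-fold higher number from compound 1 to compound 3 (0.00 log units; within the scatter) to stay within the scatter, with no clear direction. For compound 3 in this assay I estimate 16 ug/mL, with a likely range from 8 ug/mL to 32 ug/mL.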

Compound 3, half-maximal inhibitory concentration: 16 ug/mL
The estimate for compound 3 equals the measured number at the digits printed, and the stated range covers the measured number.
By their numbers in this assay, from the lowest: compounds 2, 1 and 3 (each within the scatter of the next).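

On this saturated ring carbon, acetoxy in place of acetamido gives a 1.0-fold higher number from compound 1 to compound 3 (0.00 log units; within the scatter) in this assay, so compound 1 and compound 3 cannot be told apart on this read-out. The acetamido group counts 1 hydrogen-bond donor and the acetoxy group 0 hydrogen-bond donors, yet this difference between the two compounds leaves no step beyond the scatter in this assay. No measurement on these compounds gives a reason for this result.

This one swap keeps the group at 4 heavy atoms, so it cannot say whether a smaller hydroxyl group, a free amine or a longer chain such as butyramido on the same ring carbon would also stay within the scatter. It also leaves open whether the other acetoxy groups on the sugar ring tolerate such swaps equally.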